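The source may report more compounds than this note shows. Statements on the series, on what has been measured and on what is new or still open speak of the compounds shown alone.

In a functional assay on Jurkat cells (Homo sapiens) for inhibition, read by MTT assay, with a stated time of 72 h (a lower number here means a stronger inhibitor of growth, a higher number a weaker inhibitor of growth), compound 1 `COC(=O)c1nc(C)n(-c2cccc(C(F)(F)F)c2)n1` gives 10600 nM. Compound 2 `COC(=O)c1nc(C)n(-c2ccc(Cl)cc2)n1` gives 65900 nM. Compound 3 `COC(=O)c1nc(C(C)C)n(-c2ccc(F)cc2)n1` gives > 100000 nM, which is a limit of the assay and not a number.

Compound 3 therefore stands at the weak end of the three results, with only a limit to its name (the limit of > 100000 nM in this assay, at which 1 of the 3 values shown sits). Compound 4 `COC(=O)c1nc(-c2ccc[nH]2)n(-c2ccc(F)cc2)n1` carries 1H-pyrrol-2-yl in place of isopropyl on an aromatic carbon. Going by the values given here, no measured pair shows the effect of such a change, and the value of compound 3 is only a limit, so there is no number to step from; compounds 1 and 2 merely show where numbers in this assay have fallen. Compound 4 is expected with wide uncertainty, estimated at 50000 nM between 12000 nM and 100000 nM. This would be an expected step of an at least 2.0-fold lower number from compound 3 to compound 4 (0.30 log units; that floor lies within the scatter) toward stronger growth inhibition.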

Compound 4, concentration for 50% growth inhibition: 9010 nM
The estimate for compound 4 lay 5.5-fold (0.74 log units) above the measured number, outside the stated range (below it).
By their numbers in this assay, from the lowest: compounds 4 and 1 (each within the scatter of the next); then compound 2. At a limit, above all of these: compound 3.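

In this assay, the aromatic carbon between two ring nitrogen atoms proves sensitive to what it carries: 1H-pyrrol-2-yl in place of isopropyl gives an at least 11-fold lower number from compound 3 to compound 4 (1.04 log units; beyond the scatter). The earlier compounds shown here offered no single-place step at this position. Compound 3 sits at a limit, so this step is only a bound on the true size: the limit of > 100000 nM in this assay, at which 1 of the 4 values shown sits.

As far as these compounds go, it remains open whether phenyl or an amine at this position would give a similar step. Also open, from the compounds shown here alone, is whether the pyrrole ring hydrogen on nitrogen is needed, which an N-methylpyrrole would test.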